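Isobutyl gives way to 2-(pyridin-4-yl)ethenyl in compound 3

This account rests on a few compounds, and the source may have more. Where it says the series, first, only, none or still open, it means among the compounds named here.

In a functional assay on NCI-H460 cells (Homo sapiens) for cytotoxicity, read by MTT assay, with a stated time of 48 h (a lower number here means a stronger inhibitor, a higher number a weaker inhibitor), compound 1 `C=C1C(=O)O[C@H]2CC3=C[C@H](C/C(C)=C/[C@@H](OC(=O)/C=C/c4ccc(C(F)(F)F)cc4)[C@H]12)OC3=O` gives 1400 nM and compound 2 `C=C1C(=O)O[C@H]2CC3=C[C@H](C/C(C)=C/[C@@H](OC(=O)CC(C)C)[C@H]12)OC3=O` gives 3800 nM. Compound 2 thus has the higher of the two numbers, and the gap lies beyond the usual scatter. Compound 3 `C=C1C(=O)O[C@H]2CC3=C[C@H](C/C(C)=C/[C@@H](OC(=O)/C=C/c4ccncc4)[C@H]12)OC3=O` carries 2-(pyridin-4-yl)ethenyl in place of isobutyl on a carbonyl carbon. Within the data shown here, no measured step isolates this change, so the only guide is compound 1 at 1400 nM, which also holds a six-membered aromatic ring. A modest step to a lower number is expected in this assay, a 2.1-fold lower number from compound 2 to compound 3 (0.32 log units; beyond the scatter). Compound 3 is estimated at 1800 nM, with an expected range of 700 nM to 4500 nM.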

Compound 3, half-maximal inhibitory concentration: 2100 nM
Beside the measured number, compound 3's estimate is 1.2-fold (0.07 log units) below it; the range from low to high includes it.
By their numbers in this assay, from the lowest: compounds 1, 3 and 2 (each within the scatter of the next, the first and the last beyond it).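

In this assay the change from isobutyl to 2-(pyridin-4-yl)ethenyl on a carbonyl carbon brings a 1.8-fold lower number from compound 2 to compound 3 (0.26 log units; within the scatter) and so does not clear the scatter on its own. Pyridin-4-yl in place of 4-(trifluoromethyl)phenyl on a double-bonded chain carbon gives a 1.5-fold higher number from compound 1 to compound 3 (0.18 log units; within the scatter) and likewise stays within the scatter, so these two aromatic rings cannot be told apart here. Nothing available accounts for either step. Still open, from the compounds shown here alone, is how an unsubstituted phenyl, a pyridin-3-yl ring, or a longer chain would read at this carbonyl carbon.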